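The source may report more compounds than this note shows. Statements on the series, on what has been measured and on what is new or still open speak of the compounds shown alone.

Measured in an ADME assay on microsomes from liver (Homo sapiens) for metabolic stability, with a stated time of 10 min; a lower number here means that less of the compound is left, a higher number that more of the compound is left:
- compound 1 `CCC[C@]1(C(=O)N2CC[C@](c3ccc(C(F)(C(F)(F)F)C(F)(F)F)cc3)(S(=O)(=O)c3ccc(F)cc3)C2)CC[C@H](C(=O)O)CC1`: "not determined" (no result reported)
- compound 2 `COC[C@]1(C(=O)N2CC[C@](c3ccc(C(F)(C(F)(F)F)C(F)(F)F)cc3)(S(=O)(=O)c3ccc(F)cc3)C2)CC[C@H](C(=O)O)CC1`: 100%
- compound 3 `O=C(O)C12CCC(C(=O)N3CC[C@](c4ccc(C(F)(C(F)(F)F)C(F)(F)F)cc4)(S(=O)(=O)c4ccc(F)cc4)C3)(CC1)CC2`: 100%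

Among the compounds with values here, compound 3 stands level with compound 2, the only other compound with a number in this assay. Compound 4 `O=C([C@H]1CC[C@H](CO)CC1)N1CC[C@](c2ccc(C(F)(C(F)(F)F)C(F)(F)F)cc2)(S(=O)(=O)c2ccc(F)cc2)C1` has not yet been measured. The structural change is a group of 8 heavy atoms (7 carbon, 1 oxygen; one six-membered non-aromatic ring of carbon only) in place of a group of 11 heavy atoms (9 carbon, 2 oxygen; 2 six-membered non-aromatic rings of carbon only), on a carbonyl carbon. The entering group is 4-(hydroxymethyl)cyclohexyl, with 2 defined stereocentres, and it sits on a carbonyl carbon whose other neighbour is an amide-type nitrogen in a ring.

Within the data shown here, only one measured step bears on this change: no change at the digits printed from compound 2 to compound 3 (within the scatter). It also exchanged the group on that carbonyl carbon and stayed within the scatter. Among the measured compounds shown here, this is thin support, since no measured compound carries the entering group and compound 1 offers no number for comparison. With compound 3 at 100%, the read-out has no room to show a gain, so any real movement can only be downward. A fall is therefore expected, though a result still within the scatter remains possible, and the estimated size is a number 20 percentage points lower from compound 3 to compound 4 (beyond the scatter). For compound 4 the estimate is 80%, with an expected range of 50% to 100%.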

Compound 4, percent of the compound remaining: 75%
Compound 4: the middle estimate sits 5 percentage points above what was measured; the measured number falls inside the stated range.
By their numbers in this assay, from the lowest: compound 4; then compounds 2 and 3 (each within the scatter of the next).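

In this assay the group on the carbonyl carbon can move the read-out after all: the step is a number 25 percentage points lower from compound 3 to compound 4 (beyond the scatter), and likewise a number 25 percentage points lower from compound 2 to compound 4 (beyond the scatter), whereas the earlier exchange gave no change at the digits printed from compound 2 to compound 3 (within the scatter). Among the three compounds with numbers, the two carrying a carboxy group on the cyclohexane or bicyclic group stay level, and only compound 4, with 4-(hydroxymethyl)cyclohexyl, stands lower, so the position tolerates some exchanges but not every one. Nothing shown gives a reason for this fall.

Each step exchanges the whole group on the carbonyl carbon, so the loss of the carboxy group cannot be separated from the loss of the second ring in compound 3 or of the methoxymethyl substituent in compound 2, and compound 1 adds no comparison. A plain 4-carboxycyclohexyl group would separate these changes, while an aminomethyl group in place of the hydroxymethyl would show whether compound 4's lower level is particular to the hydroxymethyl group.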